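Replacing Propyl by Chlorophenyl in a Series at the Limit

A few compounds are considered here, and "the series" means these few. Any claim that something is new, unique, unknown or untested is made for them only; others in the source may bear on it.

Compound 1 `CC1CN(C(N)=S)N=C1c1ccccc1`, compound 2 `CCCCNC(=S)N1CC(C)C(c2ccccc2)=N1` and compound 3 `Cc1ccccc1NC(=S)N1CC(C)C(c2ccccc2)=N1` share one core and differ only in the group on an amide-type nitrogen. In an ADME assay on KB cells (Homo sapiens) for cytotoxicity, read by MTT assay, with a stated time of 44 h (a higher number here means a weaker inhibitor, a lower number a stronger inhibitor), compound 1 gives > 100000 nM, which is a limit of the assay rather than a number. Compound 2 gives > 100000 nM in this assay, again only a limit. Compound 3 reaches only the limit > 100000 nM in this assay. Because all three values sit at the same limit (the limit of > 100000 nM in this assay, at which 3 of the 3 values shown sit), the steps a step that the two limits leave unreadable from compound 1 to compound 2, a step that the two limits leave unreadable from compound 1 to compound 3 and a step that the two limits leave unreadable from compound 2 to compound 3 cannot be read. Compound 4 `CC1CN(C(=S)NCc2ccccc2Cl)N=C1c1ccccc1` differs from compound 2 by 2-chlorophenyl in place of propyl on a saturated chain carbon bound to an amide-type nitrogen. Among the compounds with values here, no measured step bears on this change, so no size or direction is expected beyond the scatter. Compound 4 is therefore estimated at 200000 nM, between 100000 nM and 1000000 nM, a step that the limit leaves unreadable from compound 2 to compound 4 that is expected to remain at the limit.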

Compound 4, half-maximal inhibitory concentration: > 100000 nM
Compound 4: no number, only a limit; the forecaster's own chance of this, stated with the estimate: 85%; the middle value is on the limit's open side.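

The step from compound 2 to compound 4 cannot be read, because both values are limits rather than numbers: the limit of > 100000 nM in this assay, at which 4 of the 4 values shown sit. The compounds shown leave open how far each lies beyond that limit, and whether any group on the amide-type nitrogen would give a readable value.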